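Replacing (methoxycarbonyl)amino with methyl on compound 1

The compounds below may be only part of what the source reports. "The series", "measured", "known", "first", "only" and "open" are said of these compounds alone.

Measured in a functional assay on the whole organism (arterial blood) with Rattus norvegicus as the target; on this read-out higher numbers stand for an effect only at larger amounts of compound and lower numbers for an effect already at smaller amounts:
- compound 1 `COC(=O)NC(CC(=O)N1CCC(Cn2c(C)nc3cnccc32)CC1)c1ccccc1`: 0.035 mg/kg
- compound 2 `Cc1nc2cnccc2n1C1CCN(C(=O)CC(c2ccccc2)c2ccccc2)CC1`: 0.41 mg/kg
- compound 3 `COC(=O)NC(CC(=O)N1CCC(n2c(C)nc3cnccc32)CC1)c1ccccc1`: 0.56 mg/kg

Compound 1 has the lowest number of the three, and compounds 2 and 3 both lie above it, beyond the scatter. Compound 4 `Cc1nc2cnccc2n1CC1CCN(C(=O)CC(C)c2ccccc2)CC1` is compound 1 with one change, methyl in place of (methoxycarbonyl)amino on a saturated chain carbon bound to an aromatic carbon and a saturated chain carbon.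

Among the compounds with values here, one measured step bears on this place: a 1.4-fold higher number from compound 2 to compound 3 (0.14 log units; within the scatter). That step was small, but it swapped phenyl rather than methyl, and both its compounds differ from compound 1 elsewhere. A modest rise in this assay is therefore expected, with wide uncertainty. The estimated change is a 2.6-fold higher number from compound 1 to compound 4 (0.41 log units; beyond the scatter). For compound 4 the expected value is 0.09 mg/kg, within an estimated range of 0.02 mg/kg to 0.4 mg/kg.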

Compound 4, dose for 50% inhibition: 0.033 mg/kg
Estimate against measurement, compound 4: 2.7-fold (0.44 log units) above; the range from low to high includes it.
By their numbers in this assay, from the lowest: compounds 4 and 1 (each within the scatter of the next); then compounds 2 and 3 (each within the scatter of the next).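

In this assay, this position accepts the swap with no measurable loss: the result is a 1.1-fold lower number from compound 1 to compound 4 (0.03 log units; within the scatter), so the much smaller methyl serves as well as (methoxycarbonyl)amino here. The earlier swap at this place, between compounds 2 and 3, sat on a different core, while this one tests the core of compound 1 directly. Nothing measured here bears on why the two groups read alike. As far as these compounds go, it remains open whether this tolerance extends to an amine, a carboxylic acid or a longer chain at this carbon.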